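This account rests on a few compounds, and the source may have more. Where it says the series, first, only, none or still open, it means among the compounds named here.

Of the compounds shown here, two of this set have been measured in an assay on cells for positive allosteric modulation of Cystic fibrosis transmembrane conductance regulator variant F508del (Homo sapiens), read by fluorescence, with a stated time of 24 h; on this read-out higher numbers stand for an effect only at larger amounts of compound and lower numbers for an effect already at smaller amounts. Compound 1 `COc1ccc(S(=O)(=O)N2CCN(c3nc4ccc(C)cc4cc3C#N)CC2)cc1` gives 3800 nM. Compound 2 `Cc1cc(C)c2cc(C#N)c(NCCNC(=O)c3cccs3)nc2c1` gives 14000 nM, the higher of the two numbers, and the gap to compound 1 lies beyond the usual scatter, so compound 2 is the weaker of the pair on this read-out. Compound 3 `COc1cccc(C(=O)NCCNc2nc3cc(C)cc(C)c3cc2C#N)c1` has not yet been measured. It differs from compound 2 in one place: 3-methoxyphenyl in place of thiophen-2-yl on a carbonyl carbon. Among the compounds with values here, no measured pair shows this exchange, so the data give no size or direction for it. A step no larger than the scatter, in either direction, seems the most likely outcome in this assay. Compound 3 is therefore expected to give about 10000 nM, within a range from 3000 nM to 30000 nM. The step of a 1.4-fold lower number from compound 2 to compound 3 (0.15 log units; within the scatter) that this estimate implies is expected to be small.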

Compound 3, half-maximal effective concentration: 14000 nM
Estimate against measurement, compound 3: 1.4-fold (0.15 log units) below, within the range that was stated.
By their numbers in this assay, from the lowest: compound 1; then compounds 2 and 3 (each within the scatter of the next).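

In this assay, putting 3-methoxyphenyl in place of thiophen-2-yl on a carbonyl carbon gives no change at the digits printed from compound 2 to compound 3 (within the scatter). Within the data shown here, this is the first measured exchange at this position, and it shows that a six-membered aromatic ring of carbon only, with 8 heavy atoms, reads the same here as a five-membered aromatic ring with 5 heavy atoms, one of them sulfur. Nothing available explains why these two groups give matching numbers.

Going by these compounds, both groups are aromatic rings, so it remains open how a cyclohexyl ring, a short alkyl chain, or a group carrying an amine or a carboxylic acid would read on this carbonyl carbon. On these data alone, this is also a single pair, so whether the exchange would behave the same way on another core remains unknown.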